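Shortening the alkyl chain on the phosphate of compound 1

The compounds below may be only part of what the source reports. "The series", "measured", "known", "first", "only" and "open" are said of these compounds alone.

Compound 1 `CCCCCCCCCCOP(=O)(O)OCCSC(=S)N1CCCC1` is the anchor of the series. In a functional assay on DU-145 cells (Homo sapiens) for inhibition, read by MTT assay, with stated times of 18 h and 4 h (a higher number here means a weaker inhibitor, a lower number a stronger inhibitor), compound 1 gives 46100 nM, the lowest of the two numbers in hand. Within the data shown here, its only neighbour, compound 2 `CCCCCCCCCCOP(=O)(O)OCCSC(=S)N1CCN(C)CC1`, gives 82300 nM; the step of a 1.8-fold higher number from compound 1 to compound 2 (0.25 log units; within the scatter) exchanges 4-methylpiperazin-1-yl for pyrrolidin-1-yl on a thiocarbonyl carbon, so the two compounds cannot be ranked against each other.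

Compound 3 `CCCCCCOP(=O)(O)OCCSC(=S)N1CCCC1` keeps the pyrrolidin-1-yl dithiocarbamate and the phosphate of compound 1 and alters only the alkyl chain: hydrogen in place of butyl on a saturated chain carbon, six bonds along the chain from an oxygen on an unsaturated carbon. Among the measured compounds shown here, no measured step touches this chain; the one step available concerns the amine on the thiocarbonyl carbon and was within the scatter, so it gives no guidance on the chain. With nothing to anchor a direction, the expectation for compound 3 rests on compound 1 alone and is set a little weaker, at an estimated 90000 nM with a range of 30000 nM to 270000 nM, an expected step of a 2.0-fold higher number from compound 1 to compound 3 (0.29 log units; within the scatter).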

Compound 3, half-maximal inhibitory concentration: > 100000 nM
Compound 3 ended at the assay's limit; the forecaster's own chance of this, stated with the estimate: 25%; middle value at least 1.1-fold (0.04 log units) from the limit.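

Among these compounds, replacing butyl with hydrogen at this chain position is the first change to register beyond the scatter: in this assay the result is an at least 2.1-fold higher number from compound 1 to compound 3 (0.33 log units; beyond the scatter). Compound 3 stands at a limit of the assay, not at a number: the limit of > 100000 nM in this assay, at which 1 of the 3 values shown sits. The alkyl chain on the phosphate therefore bears on the read-out, and shortening it weakens inhibition, which the exchange of amine on the thiocarbonyl carbon, a 1.8-fold higher number from compound 1 to compound 2 (0.25 log units; within the scatter), did not show.

The compounds shown leave open whether a chain longer than that of compound 1 would carry the trend further, and whether a carboxylic acid or an amine at the end of the chain would be tolerated. From the compounds shown here alone, it is also open whether the same shortening has a comparable effect with 4-methylpiperazin-1-yl on the thiocarbonyl carbon.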